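A few compounds are considered here, and "the series" means these few. Any claim that something is new, unique, unknown or untested is made for them only; others in the source may bear on it.

Measured so far:
- compound 1, `O=C(N/N=C/c1ccc(Cl)cc1)c1cccnc1Nc1cccc(C(F)(F)F)c1`: 48.5%
- compound 2, `COc1ccc(/C=N/NC(=O)c2cccnc2Nc2cccc(C(F)(F)F)c2)c(OC)c1`: 24.1%

Both compounds were tested in a functional assay on the whole organism (strain Wistar) for inhibition, with Rattus norvegicus as the target, read by paw edema, with a stated time of 3 h, at a dose of 10 mg/kg by the intraperitoneal route; on this read-out higher numbers stand for more inhibition at the one dose given (going by the name of the read-out) and lower numbers for less inhibition. Within the data shown here, compound 1 gives 48.5%, and compound 2 gives 24.1%, which is the lowest of the two numbers; its nearest neighbour is compound 1, reached by the single measured step of a number 24.4 percentage points lower from compound 1 to compound 2 (beyond the scatter).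

Compound 3, `CN(C)c1ccc(/C=N/NC(=O)c2cccnc2Nc2cccc(C(F)(F)F)c2)cc1`, has not yet been measured in this assay. It differs from compound 2 in one place: 4-(dimethylamino)phenyl in place of 2,4-dimethoxyphenyl on a carbon with a double bond to nitrogen. Among the measured compounds shown here, no measured step covers this exact exchange. For the measured compounds named here, the one step available, from compound 1 to compound 2, shows that swapping the group on this carbon can move the inhibition by a modest amount, beyond the scatter. Compound 3, like compound 1, carries a single group on its phenyl ring, which gives some reason to expect the number to move back up rather than down.

On that basis compound 3 is expected to give 36%, within a range from 16% to 56%. The expected step is a number 11.9 percentage points higher from compound 2 to compound 3 (beyond the scatter), an estimate that lies within or just beyond the scatter.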

Compound 3, a percentage reported as inhibition, in the whole organism at one dose (the size of the read-out at that dose, not a potency): 39.5%
For compound 3 the middle estimate is 3.5 percentage points below the measured one; the measured number falls inside the stated range.
By their numbers in this assay, from the lowest: compound 2; then compounds 3 and 1 (each within the scatter of the next).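

In this assay, the group on the carbon with a double bond to nitrogen can move the number upward as well as downward: the exchange of 2,4-dimethoxyphenyl for 4-(dimethylamino)phenyl gives a number 15.4 percentage points higher from compound 2 to compound 3 (beyond the scatter) and so shows that the low number of compound 2 is not shared by every replacement for 4-chlorophenyl. The other new comparison, with dimethylamino in place of chloro on an aromatic carbon, gives a number 9 percentage points lower from compound 1 to compound 3 (within the scatter) and so does not separate these two groups on this read-out, although this rests on a single pair. Among these three compounds, the two with one named group on the phenyl ring stand apart from the 2,4-dimethoxyphenyl compound, and nothing measured here explains that difference.

The compounds shown leave open whether a plain phenyl ring, or a ring carrying a single methoxy group, would stand with compound 1 and compound 3 or with compound 2. They also leave open how a carboxylic acid or a longer alkyl chain in place of chloro or dimethylamino would read in this assay on the same ring.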